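Adding One Methyl to the Propanoyl Group

The compounds below may be only part of what the source reports. "The series", "measured", "known", "first", "only" and "open" are said of these compounds alone.

Of the compounds shown here, two sharing one core have been measured so far. In an ADME assay on the whole organism for metabolic stability, with Rattus norvegicus as the target, at a dose of 10 mg/kg by the intraperitoneal route (on this read-out higher numbers stand for a longer-lived compound and lower numbers for a shorter-lived compound), compound 1 `Cc1c(OCCCCOc2ccc(F)c(C(=O)O)c2)ccc(C(=O)CC(C)(C)C)c1O` gives 1.33 h, while compound 2 `CCC(=O)c1ccc(OCCCCOc2ccc(F)c(C(=O)O)c2)c(C)c1O` gives 0.367 h, the lower of the two numbers. Compound 3 `Cc1c(OCCCCOc2ccc(F)c(C(=O)O)c2)ccc(C(=O)C(C)C)c1O` alters compound 2 in a single place: methyl in place of hydrogen on a saturated chain carbon bound to a carbonyl carbon and a saturated chain carbon. Put simply, propanoyl becomes isopropylcarbonyl, with methyl in place of hydrogen on a saturated chain carbon bound to a carbonyl carbon and a saturated chain carbon.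

Among the measured compounds shown here, only one measured step bears on this change. It also falls on a saturated chain carbon bound to a carbonyl carbon, where methyl stands in place of tert-butyl, and it is modest but beyond the scatter: a 3.6-fold lower number from compound 1 to compound 2 (0.56 log units; beyond the scatter). Compound 3 keeps a small group at this part of the molecule, and a single step cannot show how the number responds to a lesser change. A partial move back upward therefore seems likely. The expected step is a 1.7-fold higher number from compound 2 to compound 3 (0.23 log units; within the scatter), which may not clear the scatter. For compound 3 the estimated half-life is 0.62 h, with an expected range of 0.3 h to 1.3 h.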

Compound 3, half-life: 0.5 h
For compound 3 the middle estimate is 1.2-fold (0.09 log units) above the measured one; measured number inside the range.
By their numbers in this assay, from the lowest: compounds 2 and 3 (each within the scatter of the next); then compound 1.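

In this assay the extra methyl on this saturated chain carbon gives a 1.4-fold higher number from compound 2 to compound 3 (0.13 log units; within the scatter) and so turning propanoyl into isopropylcarbonyl does not separate these two compounds. Changing the other way along the series, isopropyl in place of neopentyl on the carbonyl carbon gives a 2.7-fold lower number from compound 1 to compound 3 (0.42 log units; beyond the scatter) and this shows that the gap seen earlier with the methyl change is not closed by one added methyl: compound 2 and compound 3 stand together, and compound 1 alone stands clear of them. No supporting measurement speaks to the reason for this grouping.

Still open, as far as these compounds go, is where, among the groups on the carbonyl carbon, the half-life starts to part from that of compound 2 and compound 3, and a tert-butyl or a cyclopropyl group there would help to place that point. Also open, from the compounds shown here alone, is whether the branching of neopentyl matters at all, or whether an unbranched longer chain such as butyl on the carbonyl carbon would stand with compound 1 as well.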